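This account rests on a few compounds, and the source may have more. Where it says the series, first, only, none or still open, it means among the compounds named here.

The compounds here share one core and differ in the aromatic group attached to a carbon with a double bond to nitrogen; their strength is measured in a functional assay on MGC-803 cells (Homo sapiens) for antiproliferative activity, read by MTT assay, with a stated time of 72 h; a lower number here means a stronger inhibitor, a higher number a weaker inhibitor. Compound 1 `CCCSc1nc(N/N=C/c2ccccc2F)c2nnn(Cc3ccccc3)c2n1` carries a 2-fluorophenyl group there. In this assay compound 1 gives > 64000 nM, which is a limit of the assay rather than a number. Compound 1 therefore stands at the limit of > 64000 nM in this assay, at which 1 of the 3 values shown sits. Two other compounds give numbers. Compound 3 `CCCSc1nc(N/N=C/c2ccc([N+](=O)[O-])cc2)c2nnn(Cc3ccccc3)c2n1` gives 10100 nM in this assay, and compound 2 `CCCSc1nc(N/N=C(\C)c2ccccc2O)c2nnn(Cc3cccc(Cl)c3)c2n1` gives 6500 nM. The step of an at least 6.3-fold lower number from compound 1 to compound 3 (0.80 log units; beyond the scatter) shows that exchanging the aromatic group on that carbon can bring the number down from the limit into a measurable range. Compound 4 `CCCSc1nc(N/N=C/c2c(O)ccc3ccccc23)c2nnn(Cc3ccccc3)c2n1` is not yet measured; it differs from compound 1 by 2-hydroxynaphthalen-1-yl in place of 2-fluorophenyl on a carbon with a double bond to nitrogen. Within the data shown here, that one measured step is the only guide, and it was at least modest. A drop of similar size is therefore expected, and compound 4 is estimated at 8000 nM, within 2000 nM to 40000 nM. The expected step is an at least 8.0-fold lower number from compound 1 to compound 4 (0.90 log units; beyond the scatter).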

Compound 4, half-maximal inhibitory concentration: 3710 nM
Estimate against measurement, compound 4: 2.2-fold (0.33 log units) above; low and high end bracket the measured number.
By their numbers in this assay, from the lowest: compounds 4, 2 and 3 (each within the scatter of the next, the first and the last beyond it). At a limit, above all of these: compound 1.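

Swapping in 2-hydroxynaphthalen-1-yl on the carbon with a double bond to nitrogen gives an at least 17-fold lower number from compound 1 to compound 4 (1.23 log units; beyond the scatter), showing that this position accepts a larger aromatic group with two six-membered rings. The change also gives a 2.7-fold lower number from compound 3 to compound 4 (0.43 log units; beyond the scatter), so the choice of group here does more than lift a compound off the limit: two groups that both give measured numbers can still be told apart. The first step gives only a minimum size, as the value for compound 1 is a limit of the assay and not a number: the limit of > 64000 nM in this assay, at which 1 of the 4 values shown sits.

The 2-hydroxynaphthalen-1-yl group brings the second ring and the hydroxy group together, and the compounds shown do not tell which of the two accounts for the drop. On these data alone, how a plain naphthalen-1-yl group or a phenyl ring carrying an amine would fare at this position also stays open.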